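This account rests on a few compounds, and the source may have more. Where it says the series, first, only, none or still open, it means among the compounds named here.

Measured so far in a functional assay on MGC-803 cells (Homo sapiens) for antiproliferative activity, read by MTT assay, with a stated time of 48 h; a lower number here means a stronger inhibitor, a higher number a weaker inhibitor:
compound 1 `Cc1ccc(NC(=O)Nc2cccc(CNc3nccnc3Cl)c2)cc1` gives 11900 nM
compound 2 `O=C(Nc1cccc(CNc2nccnc2Cl)c1)Nc1ccccc1Cl` gives 7130 nM
compound 3 `CN(C)c1ccc(NC(=O)Nc2cccc(CNc3nccnc3Cl)c2)cc1` gives 11500 nM

Compound 3 stands second highest of the three numbers shown; the steps of a 1.0-fold lower number from compound 1 to compound 3 (0.01 log units; within the scatter) and a 1.6-fold higher number from compound 2 to compound 3 (0.21 log units; within the scatter) are both within the scatter, so the three measured compounds sit close together. Compound 4 `COc1ccc(NC(=O)Nc2cccc(CNc3nccnc3Cl)c2)cc1` differs from compound 3 by methoxy in place of dimethylamino on an aromatic carbon. The step that bears most directly on this place is a 1.0-fold lower number from compound 1 to compound 3 (0.01 log units; within the scatter), within the scatter; the larger swap of the whole phenyl group, a 1.7-fold lower number from compound 1 to compound 2 (0.22 log units; within the scatter), is also within the scatter. No step beyond the scatter is therefore expected for compound 4 in this assay. Compound 4 is expected to give 11000 nM, with a range from 5000 nM to 25000 nM. The expected step is a 1.0-fold lower number from compound 3 to compound 4 (0.02 log units; within the scatter).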

Compound 4, half-maximal inhibitory concentration: 9240 nM
The estimate for compound 4 lay 1.2-fold (0.08 log units) above the measured number, and the stated range covers the measured number.
By their numbers in this assay, from the lowest: compounds 2, 4, 3 and 1 (each within the scatter of the next).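

In this assay, methoxy, dimethylamino and methyl on this aromatic carbon, para to a large group, cannot be told apart: a 1.2-fold lower number from compound 3 to compound 4 (0.10 log units; within the scatter) and a 1.3-fold lower number from compound 1 to compound 4 (0.11 log units; within the scatter) both stay within the scatter. Exchanging the 2-chlorophenyl for 4-methoxyphenyl, a 1.3-fold higher number from compound 2 to compound 4 (0.11 log units; within the scatter), also stays within the scatter, so this oxygen-linked group opens no separation in the series. No measurement at hand accounts for this flat reading.

Still open, going by these compounds, is whether a carboxylic acid, a primary amine or a longer alkoxy chain at this position would give a step beyond the scatter.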